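This account rests on a few compounds, and the source may have more. Where it says the series, first, only, none or still open, it means among the compounds named here.

Three compounds share one core and differ only in the side chain that hangs from the saturated chain carbon bound to an amide-type nitrogen and a carbonyl carbon. Compound 1, `NC(=O)C[C@H](NC(=O)CN(c1nc(Cl)nc2[nH]cnc12)C1CC1)C(=O)O`, carries carbamoylmethyl there; compound 2, `CC(C)[C@H](NC(=O)CN(c1nc(Cl)nc2[nH]cnc12)C1CC1)C(=O)O`, carries isopropyl; compound 3, `CC(C)C[C@H](NC(=O)CN(c1nc(Cl)nc2[nH]cnc12)C1CC1)C(=O)O`, carries isobutyl. In a functional assay on the whole organism (Tail, strain ICR) with Mus musculus as the target, in the tail flick test, with a stated time of 120 min, at a dose of 25 umol/kg by the oral route (a lower number here means a weaker effect, a higher number a stronger effect of the compound at the dose given), compound 1 gives 17%, compound 2 gives 17.1% and compound 3 gives 18.7%. The three numbers sit close together: the step of a number 0.1 percentage points lower from compound 2 to compound 1 (within the scatter), the step of a number 1.6 percentage points higher from compound 2 to compound 3 (within the scatter) and the step of a number 1.7 percentage points higher from compound 1 to compound 3 (within the scatter) all stay within the scatter of repeated measurements, so no order among them can be read.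

The change from compound 2 to compound 1 is carbamoylmethyl in place of isopropyl on a saturated chain carbon bound to an amide-type nitrogen and a carbonyl carbon. Compound 4, `NC(=O)CC[C@H](NC(=O)CN(c1nc(Cl)nc2[nH]cnc12)C1CC1)C(=O)O`, is built from compound 3 by carbamoylmethyl in place of isopropyl on a saturated chain carbon, two bonds along the chain from an amide-type nitrogen and a carbonyl carbon. This is the same kind of change, not the same one: the cores differ by isobutyl in place of isopropyl on a saturated chain carbon bound to an amide-type nitrogen and a carbonyl carbon, and the change sits one bond further out along the chain, two bonds along the chain from the amide-type nitrogen and the carbonyl carbon rather than bound to them directly.

Because the earlier step of a number 0.1 percentage points lower from compound 2 to compound 1 (within the scatter) did not move the read-out, a similarly small step a number 1.2 percentage points lower from compound 3 to compound 4 (within the scatter) is expected here. Compound 4 is therefore expected to give about 17.5% in this assay, with a likely range from 8% to 28%.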

Compound 4, a percentage reported as activity, at one dose (the size of the read-out at that dose, not a potency): 17.8%
For compound 4 the middle estimate is 0.3 percentage points below the measured one; the measured number falls inside the stated range.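

Placing carbamoylmethyl in place of isopropyl on the core of compound 3 gives a number 0.9 percentage points lower from compound 3 to compound 4 (within the scatter) in this assay, and this step agrees with the earlier one on the other core: the same change on two cores in this assay, a number 0.1 percentage points lower (within the scatter) from compound 2 to compound 1 and a number 0.9 percentage points lower (within the scatter) from compound 3 to compound 4, 0.8 percentage points apart, within the scatter of two such steps

The remaining new comparisons are also too small to read, with a number 0.7 percentage points higher from compound 2 to compound 4 (within the scatter) and a number 0.8 percentage points higher from compound 1 to compound 4 (within the scatter), so no order can be drawn among the four compounds. Within the data shown here, this shows only that the change produced no step distinguishable from scatter on either of these two cores, in this one test at one dose and one time. It does not show that the change would carry over in the same way where a side chain has a clear effect, or on any other core, since a match between two steps this small says little about how the change transfers.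

Still open, on these data alone, is whether a side chain ending in an amine or a carboxylic acid, a benzyl group, or a longer chain than isobutyl or 2-carbamoylethyl would give a read-out clearly separate from these four. Also open, as far as these compounds go, is whether the four compounds would stay this close together at another dose or another time.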